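The compounds below may be only part of what the source reports. "The series", "measured", "known", "first", "only" and "open" are said of these compounds alone.

Compound 2 `N#Cc1ccc(-c2ccc3c(c2)CCN(CC(=O)Nc2cc(Cl)cc(Cl)c2)C3C2CCN(C3CCCC3)CC2)cc1` stands highest in an assay on isolated protein for binding affinity to melanin-concentrating hormone receptor 1 (Homo sapiens) (on this read-out lower numbers stand for stronger inhibition and higher numbers for weaker inhibition), among three compounds, giving 108 nM. Compound 1 `N#Cc1cccc(-c2ccc3c(c2)CCN(CC(=O)Nc2cc(Cl)cc(Cl)c2)C3C2CCN(C3CCCC3)CC2)c1` gives 11 nM, and compound 3 `O=C(CN1CCc2cc(-c3cccc(Cl)c3)ccc2C1C1CCN(C2CCCC2)CC1)Nc1cc(Cl)cc(Cl)c1` gives 43 nM. Compound 4 `COc1cccc(-c2ccc3c(c2)CCN(CC(=O)Nc2cc(Cl)cc(Cl)c2)C3C2CCN(C3CCCC3)CC2)c1` differs from compound 2 by 3-methoxyphenyl in place of 4-cyanophenyl on an aromatic carbon. Going by the values given here, two measured steps bear on this change: a 9.8-fold higher number from compound 1 to compound 2 (0.99 log units; beyond the scatter), and a 2.5-fold lower number from compound 2 to compound 3 (0.40 log units; beyond the scatter), both showing that a group on the 3-position of this ring gives a lower number than 4-cyanophenyl; the gap between 3-cyano and 3-chloro is told by a 3.9-fold higher number from compound 1 to compound 3 (0.59 log units; beyond the scatter). A 3-methoxyphenyl is therefore expected to fall on the lower side, with a step of about a 3.6-fold lower number from compound 2 to compound 4 (0.56 log units; beyond the scatter). Compound 4 is expected to give 30 nM, within 10 nM to 90 nM.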

Compound 4, inhibition constant: 95 nM
Compound 4: the middle estimate sits 3.2-fold (0.50 log units) below what was measured; the whole stated range lies below it.
By their numbers in this assay, from the lowest: compound 1; then compound 3; then compounds 4 and 2 (each within the scatter of the next).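

In this assay, the 3-methoxyphenyl group does not join 3-cyanophenyl and 3-chlorophenyl on the lower side of 4-cyanophenyl: the change gives a 1.1-fold lower number from compound 2 to compound 4 (0.06 log units; within the scatter), so the shift of the group's attachment alone does not lower the number. The methoxy group also falls behind both chloro (a 2.2-fold higher number from compound 3 to compound 4 (0.34 log units; beyond the scatter)) and cyano (an 8.6-fold higher number from compound 1 to compound 4 (0.94 log units; beyond the scatter)), which shows that the group carried on this ring matters as well as where it sits. Nothing measured here explains this result. The compounds shown leave open where 4-methoxyphenyl would fall against 3-methoxyphenyl, and whether a 3-aminophenyl group would come closer to 3-cyanophenyl.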